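This account rests on a few compounds, and the source may have more. Where it says the series, first, only, none or still open, it means among the compounds named here.

Measured compounds in an ADME assay on BEAS-2B cells (Homo sapiens) for cytotoxicity, read by MTT assay, with a stated time of 72 h; a higher number here means a weaker inhibitor of growth, a lower number a stronger inhibitor of growth:
Compound 1 `CCCCC[Se]c1nc(NCc2ccc(SC)cc2)c2ccccc2n1`: compound 1 gives 88200 nM.
Compound 2 `CSc1ccc(CNc2nc([SeH])nc3ccccc23)cc1`: compound 2 gives 58200 nM.
Compound 3 `Nc1nc([SeH])nc2ncccc12`: compound 3 gives 87700 nM.

Compound 4 `CCCCC[Se]c1nc(N)c2cccnc2n1` has not yet been measured in this assay. It differs from compound 3 by pentyl in place of hydrogen on a selenium. The same change separates compound 2 from compound 1, namely (pentyl in place of hydrogen on a selenium), and in this assay that step was a 1.5-fold higher number from compound 2 to compound 1 (0.18 log units; within the scatter). The difference between the core of compound 3 and the core of compound 2 is not broken down here. The three measured values all lie within the scatter of one another. Because the earlier step of a 1.5-fold higher number from compound 2 to compound 1 (0.18 log units; within the scatter) stayed within the scatter, compound 4 is expected to move only slightly from compound 3, by about a 1.3-fold higher number from compound 3 to compound 4 (0.12 log units; within the scatter). Compound 4 is therefore estimated at 115000 nM in this assay, with a plausible range from 60000 nM to 220000 nM.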

Compound 4, concentration for total growth inhibition: 44900 nM
Compound 4: the middle estimate sits 2.6-fold (0.41 log units) above what was measured, and the stated range ends above it.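

In this assay pentyl in place of hydrogen on a selenium gives a 2.0-fold lower number from compound 3 to compound 4 (0.29 log units; within the scatter) on the core of compound 3, and the two pairs that carry this change do not agree: the same change on two cores in this assay, a 1.5-fold higher number (0.18 log units; within the scatter) from compound 2 to compound 1 and a 2.0-fold lower number (0.29 log units; within the scatter) from compound 3 to compound 4, 3.0-fold (0.47 log units) apart, beyond the scatter of two such steps.
The effect of this change therefore did not carry over unaltered between these two cores, although each step taken alone stays within the scatter. This does not show that pentyl reliably strengthens or weakens growth inhibition on either core, and two pairs cannot set a rule for the series.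

The compounds shown leave open how a shorter chain such as methyl, or a benzyl group, would behave on the selenium. They also leave open whether a further core would follow the step to compound 1 or the step to compound 4.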